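The source may hold more compounds than are shown below. What is called first, only, known or untested is meant among the compounds shown, and "the series" means these compounds.

Working notes on the series, read in a functional assay on HT-29 cells (Homo sapiens) for inhibition, with a stated time of 72 h; on this read-out higher numbers stand for weaker inhibition and lower numbers for stronger inhibition. Compound 1 `COc1cc(C(=O)c2ccc3cc[nH]c3c2)cc(OC)c1OC` gives 330 nM, compound 2 `COc1cc(C(=O)c2cccc3c2ccn3C)cc(OC)c1OC` gives 22.4 nM, and compound 3 `CCn1ccc2cc(C(=O)c3cc(OC)c(OC)c(OC)c3)ccc21` gives 32 nM. Compound 3 cannot be separated from compound 2, as their two numbers lie within the scatter of each other. Compound 1 has a clearly higher number than compound 3, beyond the scatter, so compound 3 sits with compound 2 at the stronger end of these three.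

Compound 4 `COc1cc(C(=O)c2ccc3c(ccn3CCN(C)C)c2)cc(OC)c1OC` differs from compound 3 in one place: dimethylamino in place of hydrogen on a saturated chain carbon, two bonds along the chain from an aromatic nitrogen. This is dimethylamino in place of hydrogen on a saturated chain carbon, two bonds along the chain from an aromatic nitrogen, turning ethyl into 2-(dimethylamino)ethyl. Within the data shown here, no measured pair isolates this change, so the expectation is loose: a modest step in this assay toward weaker inhibition, which may not clear the scatter. The expected move is a 1.9-fold higher number from compound 3 to compound 4 (0.27 log units; within the scatter). For compound 4 the estimate is 60 nM, with an expected range of 15 nM to 250 nM.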

Compound 4, half-maximal inhibitory concentration: 4600 nM
The estimate for compound 4 lay 77-fold (1.88 log units) below the measured number; measured number above the stated range.
By their numbers in this assay, from the lowest: compounds 2 and 3 (each within the scatter of the next); then compound 1; then compound 4.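

In this assay, turning ethyl into 2-(dimethylamino)ethyl gives a 140-fold higher number from compound 3 to compound 4 (2.16 log units; beyond the scatter), a large loss of inhibition from a single change. Among these compounds, the earlier compounds carry no substituent on a saturated chain carbon, two bonds along the chain from an aromatic nitrogen, so this is the first sign that this place does not freely accept dimethylamino. No measurement in hand accounts for the size of this step.

The compounds shown leave open whether the loss belongs to dimethylamino specifically or to any group at this place, which a hydroxyl or methoxy group on the same chain carbon would begin to separate. Also open, on these data alone, is whether a longer chain carrying the same dimethylamino, or a morpholine in its place, would behave the same way.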